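Working notes: from compound 2 to compound 3

The compounds below may be only part of what the source reports. "The series", "measured", "known", "first", "only" and "open" are said of these compounds alone.

Values so far in an ADME assay on THP-1 cells (Homo sapiens) for cytotoxicity, read by flow cytometry and propidium iodide staining, with a stated time of 72 h (a higher number here means a weaker inhibitor, a lower number a stronger inhibitor), are as follows
- compound 1 `COc1cccc(-c2oc3ccc(NC(C)=O)cc3c(=O)c2O)c1` (50000 nM)
- compound 2 `Nc1ccc2oc(-c3ccccc3)c(O)c(=O)c2c1` (27000 nM)

Among the compounds with values here, compound 2 (27000 nM) stands within the scatter of compound 1 (50000 nM), the only other measured value. Compound 3 `COc1cccc(-c2oc3ccc(N)cc3c(=O)c2O)c1` has not yet been measured in this assay and differs from compound 2 by methoxy in place of hydrogen on an aromatic carbon of a six-membered aromatic ring of carbon only, meta to a large group methoxy in place of hydrogen on an aromatic carbon as counted. Within the data shown here, no measured pair isolates this change. Compound 1 also carries methoxy, and its value stays within the scatter of that of compound 2, which is thin support. The expected step (a 1.1-fold higher number from compound 2 to compound 3 (0.05 log units; within the scatter)) is estimated to stay within the scatter, with no firm direction. Compound 3 is estimated at 30000 nM with an expected range from 12000 nM to 65000 nM for the coming measurement.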

Compound 3, half-maximal inhibitory concentration: 2000 nM
Compound 3: the middle estimate sits 15-fold (1.18 log units) above what was measured; the measured number lies below the stated range.
By their numbers in this assay, from the lowest: compound 3; then compounds 2 and 1 (each within the scatter of the next).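

In this assay, methoxy in place of hydrogen on an aromatic carbon, meta to a large group, gives a 14-fold lower number from compound 2 to compound 3 (1.13 log units; beyond the scatter). This change thus counts for far more at this place than compounds 1 and 2 alone could show. With methoxy held constant, hydrogen in place of acetyl on a nitrogen on an aromatic ring gives a 25-fold lower number from compound 1 to compound 3 (1.40 log units; beyond the scatter) as well, so the low number among these compounds appears only where methoxy and the free nitrogen occur together, as in compound 3. Nothing at hand gives a reason for either step.

Within the data shown here, whether the methoxy step depends on the free nitrogen remains open, since no pair shows methoxy entering with acetyl on that nitrogen. Also open, going by these compounds, is whether a hydroxyl, an ethoxy or a chlorine at this place would match methoxy.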